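The source may report more compounds than this note shows. Statements on the series, on what has been measured and on what is new or still open speak of the compounds shown alone.

Working notes on the series.

For the measured compounds named here, compound 1 `Cc1nc(SCC(=O)Nc2nc(-c3ccc(Cl)cc3)cs2)n(Nc2ccccc2)c1C` gives 1900 nM in a functional assay on SF-539 cells (Homo sapiens) for antiproliferative activity, read by sulforhodamine B assay, with a stated time of 48 h (on this read-out lower numbers stand for stronger inhibition of growth and higher numbers for weaker inhibition of growth), the lower of the two numbers so far. Compound 2 `Cc1ccc(Nn2c(SCC(=O)Nc3nc(-c4ccccc4)cs3)nc(C)c2C)cc1` gives 4680 nM in this assay. Going by the values given here, the two differ in more than one place, so no single step connects them.

Compound 3 `COc1ccc(Nn2c(SCC(=O)Nc3nc(-c4ccc(Cl)cc4)cs3)nc(C)c2C)cc1` differs from compound 1 by one change: methoxy in place of hydrogen on an aromatic carbon, on the anilino ring. Among the compounds with values here, no measured pair isolates this change, and compound 2 carries a different group at that site alongside a second difference. The step is expected to be small, none beyond the scatter, as a 1.2-fold higher number from compound 1 to compound 3 (0.06 log units; within the scatter). Compound 3 is estimated at 2200 nM, with a range of 900 nM to 5500 nM.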

Compound 3, concentration for 50% growth inhibition: 4150 nM
The estimate for compound 3 lay 1.9-fold (0.28 log units) below the measured number; low and high end bracket the measured number.
By their numbers in this assay, from the lowest: compound 1; then compounds 3 and 2 (each within the scatter of the next).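

Methoxy in place of hydrogen on an aromatic carbon of the anilino ring, para to a large group, gives a 2.2-fold higher number from compound 1 to compound 3 (0.34 log units; beyond the scatter) in this assay and so provides the first single-change reading at this position. The step is modest, yet it shows that this position is not indifferent to substitution and that, in the setting of compound 1, phenyl to 4-methoxyphenyl weakens inhibition of growth. Nothing on hand accounts for the step.

Open, as far as these compounds go, is whether a hydroxyl, an amine or a chlorine on that same carbon would move the number in the same direction. A single pair also leaves open whether methoxy gives a similar step on other members of the series.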